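Taking one fluoro off compound 1

A few compounds are considered here, and "the series" means these few. Any claim that something is new, unique, unknown or untested is made for them only; others in the source may bear on it.

In an ADME assay on MT4 cells (Homo sapiens) for cytotoxicity, with a stated time of 5 days (a lower number here means that less compound is tolerated, a higher number that more compound is tolerated), compound 1 `O=C1CN(S(=O)(=O)c2cc(F)cc(F)c2)c2cc(Cl)ccc2N1` gives 187000 nM. Compound 3 `O=c1[nH]c2ccc(Cl)cc2n1S(=O)(=O)c1cccc(F)c1` gives 128000 nM, and these two values lie within the usual scatter of each other. Compound 2 `O=c1[nH]c2ccc(Cl)cc2n1S(=O)(=O)c1ccccc1F` gives > 382000 nM, which is a limit of the assay and not a number.

Compound 4 `O=C1CN(S(=O)(=O)c2cccc(F)c2)c2cc(Cl)ccc2N1` has not been measured yet. It differs from compound 1 by hydrogen in place of fluoro on an aromatic carbon. Within the data shown here, no measured step makes this exact change. The nearest is an at least 2.9-fold lower number from compound 2 to compound 3 (0.47 log units; beyond the scatter), which lies beyond the scatter, but it moves a fluoro group to another place on a different core and removes nothing. It is therefore only a loose guide, showing that a fluoro change can register in this pair. With nothing closer to go on, no step beyond the scatter is expected in this assay, and the estimated change is a 1.1-fold lower number from compound 1 to compound 4 (0.04 log units; within the scatter). Compound 4 is expected at 170000 nM, with an estimated range of 75000 nM to 370000 nM.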

Compound 4, half-maximal cytotoxic concentration: 189000 nM
Beside the measured number, compound 4's estimate is 1.1-fold (0.05 log units) below it; the measured number falls inside the stated range.
By their numbers in this assay, from the lowest: compounds 3, 1 and 4 (each within the scatter of the next). At a limit, above all of these: compound 2.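

Hydrogen in place of fluoro on an aromatic carbon, meta to a fluoro group, is the first change here that removes a group outright, and in this assay it gives a 1.0-fold higher number from compound 1 to compound 4 (0.00 log units; within the scatter). On this core, then, this fluoro can leave without a shift beyond the scatter, a more direct reading than the fluoro move on a different core, an at least 2.9-fold lower number from compound 2 to compound 3 (0.47 log units; beyond the scatter). Compound 2 alone stands at a limit, which is not a number: the limit of > 382000 nM in this assay, at which 1 of the 4 values shown sits.

The compounds shown place only fluoro and hydrogen at this position, so the effect of an amine, a methoxy group or a carboxylic acid there remains open. Also open, from the compounds shown here alone, is what would follow if the fluoro that remains in compound 4 gave way to hydrogen as well.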